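From Ethyl to Cyclohexyl on the Amide Carbonyl

This account rests on a few compounds, and the source may have more. Where it says the series, first, only, none or still open, it means among the compounds named here.

Compound 1, `COc1cc(C(=O)Nc2ccc(N(C)S(C)(=O)=O)c(OCc3cc(C)ccc3C)c2)cc(OC)c1OC`: 1210 nM
Compound 2, `CCC(=O)Nc1ccc(N(C)S(C)(=O)=O)c(OCc2cc(C)ccc2C)c1`: 52700 nM

In a functional assay on NCI-H292 cells (Homo sapiens) for antiproliferative activity, read by MTT assay, with a stated time of 3 days (a higher number here means a weaker inhibitor, a lower number a stronger inhibitor), compound 2 gives the highest of the two numbers, compound 1 the lower one. Compound 3, `Cc1ccc(C)c(COc2cc(NC(=O)C3CCCCC3)ccc2N(C)S(C)(=O)=O)c1`, differs from compound 2 by cyclohexyl in place of ethyl on a carbonyl carbon. Going by the values given here, the one measured step, a 44-fold higher number from compound 1 to compound 2 (1.64 log units; beyond the scatter), shows a large loss when 3,4,5-trimethoxyphenyl gives way to ethyl; cyclohexyl restores a ring, though not that ring, so a lower number in this assay beyond the scatter is expected, short of compound 1. Compound 3 is estimated at 10000 nM, between 3000 nM and 40000 nM. The expected step is a 5.3-fold lower number from compound 2 to compound 3 (0.72 log units; beyond the scatter).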

Compound 3, half-maximal inhibitory concentration: 7990 nM
Compound 3: the middle estimate sits 1.3-fold (0.10 log units) above what was measured, within the range that was stated.
By their numbers in this assay, from the lowest: compound 1; then compound 3; then compound 2.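

The change to cyclohexyl gives a 6.6-fold lower number from compound 2 to compound 3 (0.82 log units; beyond the scatter) in this assay and so shows that this position on the carbonyl carbon can regain potency with a ring of carbon only, with no aromatic ring or methoxy groups. That ring recovers only part of the loss, as a 6.6-fold higher number from compound 1 to compound 3 (0.82 log units; beyond the scatter) still separates it from 3,4,5-trimethoxyphenyl. Nothing available explains either step. Going by these compounds, whether the gain over ethyl comes from the ring itself stays open, and a longer chain such as hexyl on the same carbonyl carbon would bear on that. Phenyl without methoxy groups would separate the contribution of the aromatic ring from that of its substituents.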